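Swapping the benzimidazole end of a potent growth inhibitor

The compounds below may be only part of what the source reports. "The series", "measured", "known", "first", "only" and "open" are said of these compounds alone.

Measured in a functional assay on A549 cells (Homo sapiens) for inhibition, read by sulforhodamine B assay; on this read-out lower numbers stand for stronger inhibition of growth and higher numbers for weaker inhibition of growth:
Compound 1 `COc1ccc(-c2ccc(-c3ccc(-c4nc5cc(C)ccc5[nH]4)cc3)cc2)cc1OC`: 2100 nM
Compound 2 `COc1cc(-c2ccc(-c3ccc(-c4nc5cc(C)ccc5[nH]4)cc3)cc2)cc(OC)c1OC`: < 100 nM

Compound 2 stands at the limit of < 100 nM in this assay, at which 1 of the 2 values shown sits. As far as these compounds go, its value is a limit of the assay and not a number, so its exact position is unknown.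

Compound 2 differs from compound 1 by one methoxy in place of hydrogen on an aromatic carbon. That single change gave an at least 21-fold lower number from compound 1 to compound 2 (1.32 log units; beyond the scatter).

Compound 3 `COc1cc(-c2ccc(-c3ccc(-c4nc5c(O)cccc5[nH]4)cc3)cc2)cc(OC)c1OC` keeps the methoxy groups of compound 2 and changes the other end of the molecule, with 4-hydroxy-1H-benzimidazol-2-yl in place of 5-methyl-1H-benzimidazol-2-yl on an aromatic carbon.

Within the data shown here, no measured step covers this swap, so its direction in this assay cannot be read from the data. Among the measured compounds shown here, the methoxy step, an at least 21-fold lower number from compound 1 to compound 2 (1.32 log units; beyond the scatter), shows only that one small change can matter greatly. A modest rise in the number is expected, though a step in either direction remains possible, so the range is wide.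

The estimated step is an at least 1.5-fold higher number from compound 2 to compound 3 (0.17 log units; that floor lies within the scatter).

For compound 3, the expected value is 150 nM, with an estimated range from 30 nM to 1000 nM.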

Compound 3, concentration for 50% growth inhibition: < 100 nM
Compound 3 ended at the assay's limit (the forecaster's own chance of this, stated with the estimate: 40%); middle value at least 1.5-fold (0.17 log units) from the limit.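

Compound 2 and compound 3 each sit at a limit of the assay and not at a number, so the step between them cannot be read: the limit of < 100 nM in this assay, at which 2 of the 3 values shown sit.

As far as these compounds go, how far each compound lies past that limit stays open, and so does whether 4-hydroxy-1H-benzimidazol-2-yl in place of 5-methyl-1H-benzimidazol-2-yl changes the result in this assay at all.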